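A few compounds are considered here, and "the series" means these few. Any claim that something is new, unique, unknown or untested is made for them only; others in the source may bear on it.

Measured compounds:
compound 1, `CCS(=O)(=O)Nc1cc(-c2ccc3ncnc(Nc4cccc(F)c4)c3c2)cnc1OC`: 9940 nM
compound 2, `CCS(=O)(=O)Nc1cc(-c2ccc3ncnc(Nc4ccc(F)c(C(=O)OC)c4)c3c2)cnc1OC`: 3420 nM

In a functional assay on A549 cells (Homo sapiens) for cytotoxicity, read by sulforhodamine B assay, with a stated time of 72 h (on this read-out higher numbers stand for weaker inhibition and lower numbers for stronger inhibition), compound 1 gives 9940 nM, the highest of the two numbers; its nearest neighbour is compound 2, with a 2.9-fold lower number from compound 1 to compound 2 (0.46 log units; beyond the scatter). Compound 3, `CCS(=O)(=O)Nc1cc(-c2ccc3ncnc(Nc4ccc(OC)nc4)c3c2)cnc1OC`, differs from compound 1 in one place: 6-methoxypyridin-3-yl in place of 3-fluorophenyl on a nitrogen on an aromatic ring. For the measured compounds named here, no measured step covers this replacement. Going by the values given here, the one step in hand, a 2.9-fold lower number from compound 1 to compound 2 (0.46 log units; beyond the scatter), concerns a different group entering on the same nitrogen on an aromatic ring, and it shows that a change there can move the number modestly. Since that step involves other atoms, it gives no direction for compound 3, and the step from compound 1 to compound 3 is expected to stay within or just beyond the scatter, as a 1.2-fold lower number from compound 1 to compound 3 (0.09 log units; within the scatter). Compound 3 is therefore estimated at 8000 nM in this assay, with a range from 2500 nM to 25000 nM.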

Compound 3, half-maximal inhibitory concentration: 5560 nM
Compound 3: the middle estimate sits 1.4-fold (0.16 log units) above what was measured, and the stated range covers the measured number.
By their numbers in this assay, from the lowest: compounds 2, 3 and 1 (each within the scatter of the next, the first and the last beyond it).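

In this assay the 6-methoxypyridin-3-yl group on this nitrogen gives a 1.8-fold lower number from compound 1 to compound 3 (0.25 log units; within the scatter) and, set against the larger ester-bearing group, a 1.6-fold higher number from compound 2 to compound 3 (0.21 log units; within the scatter). Compound 3 thus lies within the scatter of both neighbours, although compound 1 and compound 2 lie beyond the scatter of each other, so a six-membered aromatic ring with a hetero atom can stand on this nitrogen with a number that cannot be told apart from either. No measurement on these compounds offers a reason for these numbers.

The step to compound 3 changes the ring atom and the methoxy group together, so the compounds shown do not separate their contributions. On these data alone, whether an amine, a carboxylic acid or a longer alkoxy chain in place of that methoxy group would carry the number beyond the scatter also remains open.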